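Growing the ether tail on a shared core

This account rests on a few compounds, and the source may have more. Where it says the series, first, only, none or still open, it means among the compounds named here.

Measured so far:
compound 1, `C=C=CCOc1cc2c(c3c1C[C@@H]1[C@@H](C)CO[C@]1(C)O3)C[C@@H]1[C@@H](C)CO[C@]1(C)O2`, gives 11000 nM
compound 2, `C#CCOc1cc2c(c3c1C[C@@H]1[C@@H](C)CO[C@]1(C)O3)C[C@@H]1[C@@H](C)CO[C@]1(C)O2`, gives 22000 nM
compound 3, `COc1cc2c(c3c1C[C@@H]1[C@@H](C)CO[C@]1(C)O3)C[C@@H]1[C@@H](C)CO[C@]1(C)O2`, gives 33000 nM

All three share one core and differ only in the group on a saturated chain carbon bound to an oxygen on an aromatic ring. In a functional assay on aorta (Rattus norvegicus, strain Sprague-Dawley) for inhibition (a lower number here means that less compound is needed, a higher number that more compound is needed for the effect), compound 1 stands lowest of the three numbers. Compound 2 is nearest: a 2.0-fold higher number from compound 1 to compound 2 (0.30 log units; within the scatter). Compound 3 is furthest: a 3.0-fold higher number from compound 1 to compound 3 (0.48 log units; beyond the scatter). Between the other two, a 1.5-fold higher number from compound 2 to compound 3 (0.18 log units; within the scatter).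

Compound 4, `C[C@H]1CO[C@]2(C)Oc3cc(OC/C=C/c4ccccc4)c4c(c3C[C@H]12)O[C@@]1(C)OC[C@H](C)[C@H]1C4`, carries a larger group at the same place: 2-phenylethenyl in place of propa-1,2-dien-1-yl on a saturated chain carbon bound to an oxygen on an aromatic ring. Within the data shown here, the steps that bear on this are those from compound 1 to compound 2 and to compound 3, where the group shrinks and the number rises, once modestly beyond the scatter and once within it. Going the other way, toward a larger group, a modest drop in the number is therefore expected, though the evidence is thin and a result within the scatter would not surprise. Compound 4 is estimated at 5000 nM, with a range of 1500 nM to 15000 nM, meaning an expected step of a 2.2-fold lower number from compound 1 to compound 4 (0.34 log units; beyond the scatter).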

Compound 4, half-maximal effective concentration: > 200000 nM
Compound 4: no number, only a limit; the forecaster's own chance of this, stated with the estimate: 10%; at least 40-fold (1.60 log units) between middle value and limit.
By their numbers in this assay, from the lowest: compounds 1, 2 and 3 (each within the scatter of the next, the first and the last beyond it). At a limit, above all of these: compound 4.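

In this assay, compound 4 gives only a limit, > 200000 nM, and not a number. This changes the picture at this position: a larger group on the saturated chain carbon does not simply bring a lower number, as the steps show: an at least 18-fold higher number from compound 1 to compound 4 (1.25 log units; beyond the scatter), an at least 9.0-fold higher number from compound 2 to compound 4 (0.95 log units; beyond the scatter) and an at least 6.0-fold higher number from compound 3 to compound 4 (0.78 log units; beyond the scatter). Among the groups shown, propa-1,2-dien-1-yl, ethynyl and hydrogen keep the numbers in a narrow span, while 2-phenylethenyl, the only one carrying a six-membered aromatic ring, moves the number far upward.

On these data alone, what remains open is whether the ring itself or the overall length of the tail matters here. A benzyl ether, with the ring on a shorter tail, and a plain butyl or hexyl chain with no ring would separate the two.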